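The source may hold more compounds than are shown below. What is called first, only, known or untested is meant among the compounds shown, and "the series" means these compounds.

Compound 1 (`CC(=O)N1CCC(c2ccc3c(c2)oc(=O)n3C(=O)NCCCCc2ccccc2)CC1`), compound 2 (`CN1CCC(c2ccc3c(c2)oc(=O)n3C(=O)NCCCCc2ccccc2)CC1=O`) and compound 3 (`CN1CCN(c2ccc3c(c2)oc(=O)n3C(=O)NCCCCc2ccccc2)C(=O)C1`) share one core and differ in the group on an aromatic carbon. In a physicochemical assay for solubility, read by HPLC, in phosphate buffer, measured as kinetic solubility, with a stated time of 1 h, at pH 7.4, tested at 250 uM (on this read-out lower numbers stand for lower solubility and higher numbers for higher solubility), compound 1 gives < 1000 nM, which is a limit of the assay and not a number. In this assay compound 2 gives 20000 nM and compound 3 gives 20000 nM. Compound 3 therefore stands level with compound 2, with no change at the digits printed from compound 2 to compound 3 (within the scatter). Both are clear of compound 1, with an at least 20-fold higher number from compound 1 to compound 2 (1.30 log units; beyond the scatter) and an at least 20-fold higher number from compound 1 to compound 3 (1.30 log units; beyond the scatter).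

Compound 4 (`CC(C)CN1CCC(c2ccc3c(c2)oc(=O)n3C(=O)NCCCCc2ccccc2)CC1`) carries 1-isobutylpiperidin-4-yl in place of 4-methyl-2-oxopiperazin-1-yl on an aromatic carbon, which amounts to 1-isobutylpiperidin-4-yl in place of 4-methyl-2-oxopiperazin-1-yl on an aromatic carbon. All three measured steps were made at this same place. The two large ones show that a change of group here can move the number a long way, while the third shows that two different groups can land level. Within the data shown here, none of the measured compounds carries an isobutyl group, so these steps give no firm direction. The expectation in this assay is therefore no step beyond the scatter, though with a wide margin on either side. The expected step is a 1.5-fold higher number from compound 3 to compound 4 (0.18 log units; within the scatter). For compound 4 the estimated value is 30000 nM, with an expected range from 3000 nM to 150000 nM.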

Compound 4, solubility: < 1000 nM
Compound 4: no number, only a limit; the forecaster's own chance of this, stated with the estimate: 15%; middle value at least 30-fold (1.47 log units) away from the limit.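

In this assay compound 4 gives < 1000 nM, which is a limit of the assay and not a number. Among these compounds, replacing either ring-carbonyl group with 1-isobutylpiperidin-4-yl brings the read-out down, with an at least 20-fold lower number from compound 3 to compound 4 (1.30 log units; beyond the scatter) and an at least 20-fold lower number from compound 2 to compound 4 (1.30 log units; beyond the scatter), so this place on the aromatic ring now has two different groups at the low end rather than only the 1-acetylpiperidin-4-yl of compound 1, while compound 2 and compound 3 remain the only compounds at the high end among the four. The change from acetyl to isobutyl on the ring nitrogen cannot be read, because compound 1 and compound 4 stand at the same limit: the limit of < 1000 nM in this assay, at which 2 of the 4 values shown sit.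

From the compounds shown here alone, how far compound 1 and compound 4 lie under that limit, and whether they differ from each other there, remains open. Also open, going by these compounds, is how a 1-methylpiperidin-4-yl group would read, since it has the methyl on the ring nitrogen of compound 2 without the ring carbonyl, and would therefore show whether the carbonyl or the isobutyl chain accounts for the gap between compound 2 and compound 4.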